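The source may hold more compounds than are shown below. What is called first, only, known or untested is meant among the compounds shown, and "the series" means these compounds.

Measured in an ADME assay on a cell-free system (plasma, Mus musculus) for metabolic stability, read by HPLC, with a stated time of 120 min, tested at 2 uM; a higher number here means that the compound lasts longer, a lower number that the compound disappears faster:
Compound 1 `Cc1ccccc1CNC(=O)n1cnc2ccccc21` gives 0.733 h.
Compound 2 `O=C(NCCCCc1ccccc1)n1cnc2ccccc21` gives > 2 h, which is a limit of the assay.
Compound 3 `Cc1ccccc1CNC(=O)n1c(N)nc2ccccc21` gives < 0.0834 h, also a limit of the assay.

Compound 3 is compound 1 with amino in place of hydrogen on an aromatic carbon. That change gives an at least 8.7-fold lower number from compound 1 to compound 3 (0.94 log units; beyond the scatter), and its size is known only as a bound because of the limit of < 0.0834 h in this assay, at which 1 of the 3 values shown sits. The difference between the core of compound 1 and that of compound 2 is not broken down here. Compound 4 `Nc1nc2ccccc2n1C(=O)NCCCCc1ccccc1`, not yet measured, is compound 2 with amino in place of hydrogen on an aromatic carbon, the same change in the same place. Compound 2 sits at a limit, as the limit of > 2 h in this assay, at which 1 of the 3 values shown sits, shows. Going by the values given here, still, that one measured drop is the only guide, and a step of similar size is expected for compound 4, an at least 10-fold lower number from compound 2 to compound 4 (1.00 log units; beyond the scatter). Compound 4 is therefore estimated at 0.2 h, with a likely range from 0.05 h to 0.9 h.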

Compound 4, half-life: 0.15 h
The estimate for compound 4 lay 1.3-fold (0.12 log units) above the measured number, within the range that was stated.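

In this assay, amino in place of hydrogen on an aromatic carbon gives an at least 13-fold lower number from compound 2 to compound 4 (1.12 log units; beyond the scatter). The direction of the change carries from one core to the other, since the number falls on both, but the two steps cannot be ranked by size: the same change on two cores in this assay, an at least 8.7-fold lower number (0.94 log units; beyond the scatter) from compound 1 to compound 3 and an at least 13-fold lower number (1.12 log units; beyond the scatter) from compound 2 to compound 4; the limit leaves it open whether they differ Two cores are also too few to show that the same drop would appear on every other core in this series.

The compounds shown leave open whether a different group on that aromatic carbon, such as methyl or hydroxyl, would lower the half-life as amino does. They also leave open whether the drop would persist on a compound with a longer chain.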